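The source may hold more compounds than are shown below. What is called first, only, known or untested is meant among the compounds shown, and "the series" means these compounds.

Of the compounds shown here, three have been measured in an in vitro functional assay on HEK ts201 cells for antagonist activity at Neuronal acetylcholine receptor; alpha3/beta4 (Homo sapiens), read by fluorescence and calcium flux; on this read-out lower numbers stand for stronger inhibition and higher numbers for weaker inhibition. Compound 1 `O=C(OCc1ccccc1-c1ccccc1)C1CCCN(CCCc2ccccc2)C1` gives 10200 nM, compound 2 `O=C(OCC1CCCNC1)c1ccccc1-c1ccccc1` gives 8130 nM, and compound 3 `O=C(CCC1CCCNC1)c1ccccc1-c1ccccc1` gives 6610 nM. Compound 2 thus holds the second highest of the three numbers; its nearest neighbour is compound 3 and its furthest is compound 1, and both gaps lie within the usual scatter of this assay, so none of the three can be called stronger or weaker than another. Compound 4 `C[N+]1(C)CCCC(COC(=O)c2ccccc2-c2ccccc2)C1` has not yet been measured. It differs from compound 2 by a group of 8 heavy atoms (7 carbon, 1 nitrogen; one six-membered non-aromatic ring with 1 hetero atom) in place of a group of 6 heavy atoms (5 carbon, 1 nitrogen; one six-membered non-aromatic ring with 1 hetero atom), on a saturated chain carbon bound to an oxygen next to a carbonyl group. For the measured compounds named here, no step between measured compounds is available to lean on, so the expectation is that the change from compound 2 to compound 4 stays within the scatter, in either direction. Compound 4 is therefore estimated at 12000 nM, between 4000 nM and 36000 nM. The expected step is a 1.5-fold higher number from compound 2 to compound 4 (0.17 log units; within the scatter).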

Compound 4, half-maximal inhibitory concentration: 6460 nM
Compound 4: the middle estimate sits 1.9-fold (0.27 log units) above what was measured; the measured number falls inside the stated range.
By their numbers in this assay, from the lowest: compounds 4, 3, 2 and 1 (each within the scatter of the next).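

For the compounds shown here, the step gives the first direct comparison at this position (a 1.3-fold lower number from compound 2 to compound 4 (0.10 log units; within the scatter)). On a saturated chain carbon bound to an oxygen next to a carbonyl group, piperidin-3-yl, with no net charge, and the larger ring group, with net charge +1 and 0 hydrogen-bond donors, cannot be told apart in this read-out. No available evidence bears on this result. Still open, going by these compounds, is how a ring nitrogen carrying a single methyl group would read, and whether an amide in place of the ester would separate from compound 2.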